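Swapping the Thiocarbonyl Amine in a Dithiocarbamate Series

The source may report more compounds than this note shows. Statements on the series, on what has been measured and on what is new or still open speak of the compounds shown alone.

Measured compounds:
- compound 1, `Nc1ccccc1NC(=O)c1ccc(CSC(=S)N2CCCc3ccccc32)cc1`: 35.7%
- compound 2, `Nc1ccccc1NC(=O)c1ccc(CSC(=S)N2CCN(c3ccc(F)cc3)CC2)cc1`: 64.5%

Of the compounds shown here, two sharing a core have been tested in a functional assay on HeLa cells (Homo sapiens) for antiproliferative activity, read by CCK-8 assay, with a stated time of 72 h, tested at 8 uM; a lower number here means a weaker effect, a higher number a stronger effect of the compound at the concentration tested. In this assay compound 1 gives 35.7%, the lower of the two numbers, while compound 2 gives 64.5%, a gap that lies beyond the usual scatter. Both carry the same core and differ only in the amine attached to the thiocarbonyl carbon.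

Compound 3, `CN(Cc1ccncc1)C(=S)SCc1ccc(C(=O)Nc2ccccc2N)cc1`, has not yet been measured. Compared with compound 1 it differs in one place: methyl((pyridin-4-yl)methyl)amino in place of 1,2,3,4-tetrahydroquinolin-1-yl on a thiocarbonyl carbon. Among the measured compounds shown here, no step between measured compounds mirrors this exact change, so the two values of compound 1 and compound 2 are the only guide, and they show that the amine on the thiocarbonyl carbon can move the read-out by a substantial amount.

For compound 3 a modest rise over compound 1 is expected, a number 10.3 percentage points higher from compound 1 to compound 3 (beyond the scatter), though it may fall within the scatter. The estimate for compound 3 in this assay is 46%, with a range from 24% to 68%.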

Compound 3, a percentage reported as inhibition, at one concentration (the size of the read-out at that concentration, not a potency): 72.7%
Compound 3: middle estimate off by 26.7 percentage points, on the low side; measured number outside the range, above it.
By their numbers in this assay, from the lowest: compound 1; then compounds 2 and 3 (each within the scatter of the next).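

In this assay, methyl((pyridin-4-yl)methyl)amino in place of 1,2,3,4-tetrahydroquinolin-1-yl on a thiocarbonyl carbon gives a number 37 percentage points higher from compound 1 to compound 3 (beyond the scatter) in a single change, a large step. The new group keeps a six-membered aromatic ring but has nitrogen in that ring, one hydrogen-bond acceptor and no non-aromatic ring, which shows that the read-out at this position does not depend on the tetrahydroquinoline or on the aryl piperazine of compound 2: compound 2 and compound 3 lie within the scatter of each other, although their amines are very different, and compound 1 alone stands apart. Nothing available here explains why this change raises the number so much.

This single swap alters several features at once, so the compounds shown cannot say whether the ring nitrogen, the open chain or the methyl group carries the gain, and a benzyl group in place of the (pyridin-4-yl)methyl group, or a pyridin-3-yl ring in place of the pyridin-4-yl ring, would begin to separate them. The read-out also comes from one concentration, so it gives the size of the effect there and leaves the potency of compound 3 open.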